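A few compounds are considered here, and "the series" means these few. Any claim that something is new, unique, unknown or untested is made for them only; others in the source may bear on it.

Two compounds share a core and differ only in the aromatic group attached to a carbonyl carbon. Compound 1 `O=C(CN1CC=CC[C@H](NC(=O)c2cc(Cl)ccc2Cl)C1=O)N[C@H]1CC(=O)OC1O` carries a 2,5-dichlorophenyl group there, and in an assay on isolated protein for inhibition of Caspase-8 (Homo sapiens) (a higher number here means a weaker inhibitor, a lower number a stronger inhibitor), compound 1 gives 554 nM. Compound 2 `O=C(CN1CC=CC[C@H](NC(=O)c2nccc3ccccc23)C1=O)N[C@H]1CC(=O)OC1O` carries an isoquinolin-1-yl group instead, and in this assay compound 2 gives 2940 nM. Compound 2 therefore stands highest of the two numbers, with compound 1 the nearest; that swap a 5.3-fold higher number from compound 1 to compound 2 (0.72 log units; beyond the scatter). Compound 3 `O=C(CN1CC=CC[C@H](NC(=O)c2ccc3ccccc3c2)C1=O)N[C@H]1CC(=O)OC1O` is the next step from compound 2: naphthalen-2-yl in place of isoquinolin-1-yl on a carbonyl carbon. Within the data shown here, only one measured step, the one from compound 1 to compound 2, bears on this position, and it shows that exchanging the aromatic group there shifts the number modestly. Since the entering group, like that of compound 1, is carbon only, compound 3 is expected to move part of the way back toward compound 1 a 2.0-fold lower number from compound 2 to compound 3 (0.29 log units; within the scatter). Compound 3 is therefore estimated at 1500 nM, within a range from 500 nM to 4500 nM.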

Compound 3, half-maximal inhibitory concentration: 2160 nM
Beside the measured number, compound 3's estimate is 1.4-fold (0.16 log units) below it; the range from low to high includes it.
By their numbers in this assay, from the lowest: compound 1; then compounds 3 and 2 (each within the scatter of the next).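

In this assay, exchanging isoquinolin-1-yl for naphthalen-2-yl on the carbonyl carbon gives a 1.4-fold lower number from compound 2 to compound 3 (0.13 log units; within the scatter), so this pair of groups of equal heavy-atom count, one with a ring nitrogen and a hydrogen-bond acceptor and one of carbon only, cannot be told apart here. Being carbon only is therefore not enough to reach the number of compound 1: exchanging 2,5-dichlorophenyl for naphthalen-2-yl gives a 3.9-fold higher number from compound 1 to compound 3 (0.59 log units; beyond the scatter), a gap that isoquinolin-1-yl and naphthalen-2-yl both show. No measurement available here accounts for that gap.

The compounds shown leave open whether the chlorine atoms of 2,5-dichlorophenyl matter at this place, which a plain phenyl group would test. They also leave open how a monochlorophenyl or a pyridyl group would compare.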